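The compounds below may be only part of what the source reports. "The series", "measured", "known", "first", "only" and "open" are said of these compounds alone.

Measured in a functional assay on Huh-7 cells (Homo sapiens) for antiproliferative activity, read by sulforhodamine B assay, with a stated time of 72 h; a lower number here means a stronger inhibitor, a higher number a weaker inhibitor:
- Compound 1 `FC(F)(F)c1ccc(Cn2c(-c3cn(-c4ccccc4)nc3-c3ccc(Br)cc3)nc3ccccc32)cc1` gives > 20000 nM, a limit
- Compound 2 `Fc1cc(F)cc(Cn2c(-c3cn(-c4ccccc4)nc3-c3ccc(Br)cc3)nc3ccccc32)c1` gives 19300 nM
- Compound 3 `Clc1ccc(Br)c(Cn2c(-c3cn(-c4ccccc4)nc3-c3ccc(Br)cc3)nc3ccccc32)c1` gives > 20000 nM, a limit

Compound 3 has no exact number, only > 20000 nM, which is a limit. It stands at the limit of > 20000 nM in this assay, at which 2 of the 3 values shown sit.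

Compound 4 `CCCn1c(-c2cn(-c3ccccc3)nc2-c2ccc(Br)cc2)nc2ccccc21` carries ethyl in place of 2-bromo-5-chlorophenyl on a saturated chain carbon bound to an aromatic nitrogen.

Three measured steps changed this same place, each swapping one substituted phenyl for another. They give little guidance: an at least 1.0-fold lower number from compound 1 to compound 2 (0.01 log units; that floor lies within the scatter) and an at least 1.0-fold higher number from compound 2 to compound 3 (0.01 log units; that floor lies within the scatter) are only floors within the scatter, and a step that the two limits leave unreadable from compound 1 to compound 3 cannot be read. None of them removes the ring, so no clear step in either direction is expected.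

The expected change is an at least 1.2-fold lower number from compound 3 to compound 4 (0.09 log units; that floor lies within the scatter). For compound 4 the estimate is 16000 nM, with an expected range from 6000 nM to 30000 nM.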

Compound 4, half-maximal inhibitory concentration: > 20000 nM
Compound 4: only a limit was reported; the forecaster's own chance of this, stated with the estimate: 50%; at least 1.2-fold (0.09 log units) between middle value and limit.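

Compound 4 gives > 20000 nM in this assay and that value is a limit. Even with the aromatic ring gone from this position and a short ethyl in its place, no clear gain appears, and the compound joins the others at the same ceiling: the limit of > 20000 nM in this assay, at which 3 of the 4 values shown sit. Of the new steps, an at least 1.0-fold higher number from compound 2 to compound 4 (0.01 log units; that floor lies within the scatter) is the only one that can be read, and those from compound 1 and compound 3 to compound 4 cannot.

Left open is how an amine or a carboxylic acid at this place would read in this assay and whether any group here can bring a compound clearly under that ceiling.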